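Homologating the ester on a hydroxypiperidine-bearing core

The compounds below may be only part of what the source reports. "The series", "measured", "known", "first", "only" and "open" are said of these compounds alone.

Measured compounds:
Compound 1, `OC1CCN(c2ccc(-c3ccc(Cl)cc3Cl)nn2)CC1`: 8.5 mg/kg
Compound 2, `CC(=O)OC1CCN(c2ccc(-c3ccc(Cl)cc3Cl)nn2)CC1`: 9.8 mg/kg

In a functional assay on the whole organism with Mus musculus as the target (a higher number here means that more compound is needed for the effect, a lower number that less compound is needed), compound 1 gives 8.5 mg/kg, and compound 2 gives 9.8 mg/kg. Going by the values given here, the two numbers sit within the scatter of each other, and the only step between measured compounds, a 1.2-fold higher number from compound 1 to compound 2 (0.06 log units; within the scatter), is the exchange of acetyl for hydrogen on the oxygen of the shared core.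

Compound 3, `CCC(=O)OC1CCN(c2ccc(-c3ccc(Cl)cc3Cl)nn2)CC1`, has not yet been measured in this assay. It differs from compound 2 by methyl in place of hydrogen on a saturated chain carbon bound to a carbonyl carbon, that is, acetyl becomes propanoyl. Among the compounds with values here, the one measured step bearing on an ester at this position, a 1.2-fold higher number from compound 1 to compound 2 (0.06 log units; within the scatter), stayed within the scatter, so a step of similar small size, or none beyond the scatter, is expected for a 1.0-fold higher number from compound 2 to compound 3 (0.01 log units; within the scatter). Compound 3 is therefore estimated at 10 mg/kg, with a range from 5 mg/kg to 20 mg/kg.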

Compound 3, dose for half-maximal effect: 16 mg/kg
Compound 3: middle estimate off by 1.6-fold (0.20 log units), on the low side, and the stated range covers the measured number.
By their numbers in this assay, from the lowest: compounds 1, 2 and 3 (each within the scatter of the next).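

With the methyl added to the acyl chain, a 1.6-fold higher number from compound 2 to compound 3 (0.21 log units; within the scatter), stays within the scatter in this assay, and so does the full change from the free hydroxyl to the propanoyl ester, a 1.9-fold higher number from compound 1 to compound 3 (0.27 log units; within the scatter). The earlier compounds shown here showed this only for acetyl; on these numbers, the propanoyl ester also cannot be told apart from either compound 1 or compound 2 at this position. Nothing at hand bears on why these numbers fall as they do.

What the compounds shown leave open is whether a longer chain, such as butanoyl, would give a step beyond the scatter. From the compounds shown here alone, it is equally open whether an amine or a carboxylic acid on the acyl chain would do so.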